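Lengthening the alkyl chain on a piperidine dithiocarbamate phosphate

The source may hold more compounds than are shown below. What is called first, only, known or untested is meant among the compounds shown, and "the series" means these compounds.

Two compounds in this set carry a phosphate ester linked through a short two-carbon spacer to a dithiocarbamate. Compound 1 `CCCCCCCCOP(=O)(O)OCCSC(=S)N1CCCCCC1` bears an octyl chain on the phosphate and a seven-membered saturated nitrogen ring. Compound 2 `CCCCCCOP(=O)(O)OCCSC(=S)N1CCCCC1` bears a hexyl chain and a six-membered saturated nitrogen ring. Both were tested in a functional assay on DU-145 cells (Homo sapiens) for inhibition, read by MTT assay, with stated times of 18 h and 4 h; on this read-out higher numbers stand for weaker inhibition and lower numbers for stronger inhibition. In this assay compound 1 gives 59100 nM. For compound 2 this assay reports only a limit, > 100000 nM, and no number; this is where compound 2 stands (the limit of > 100000 nM in this assay, at which 1 of the 2 values shown sits).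

The unmeasured compound 3 `CCCCCCCCOP(=O)(O)OCCSC(=S)N1CCCCC1` keeps the six-membered ring of compound 2 and changes only the chain: ethyl in place of hydrogen on a saturated chain carbon, six bonds along the chain from an oxygen on an unsaturated carbon. For the measured compounds named here, the chain of compound 3 thus matches that of compound 1, while its ring matches that of compound 2; no step between compound 1 and compound 3 is available, so only their values can be compared once compound 3 is measured.

With compound 2 known only as a limit, the size of the step to compound 3 cannot be fixed; a modest move toward stronger inhibition is expected, which could still lie within the scatter, an at least 1.4-fold lower number from compound 2 to compound 3 (0.15 log units; that floor lies within the scatter). Compound 3 is estimated at 70000 nM, with a range from 35000 nM to 140000 nM.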

Compound 3, half-maximal inhibitory concentration: > 100000 nM
Compound 3 gave a limit, no number; the forecaster's own chance of this, stated with the estimate: 40%; middle value at least 1.4-fold (0.15 log units) away from the limit.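

The step from compound 2 to compound 3 in this assay cannot be read, because both compounds give only a limit, so replacing hydrogen with ethyl on this saturated chain carbon produces no measurable change in inhibition: the limit of > 100000 nM in this assay, at which 2 of the 3 values shown sit.

For the compounds shown here, the one readable comparison concerns the ring rather than the chain. With the octyl chain held constant, piperidin-1-yl in place of azepan-1-yl on the thiocarbonyl carbon gives an at least 1.6-fold higher number from compound 1 to compound 3 (0.22 log units; that floor lies within the scatter). Going by these compounds alone, this is only a lower bound set by a limit, not a measured size, and compound 1 remains the only one of the three compounds with an actual number.

The compounds shown leave open how large the ring effect really is, and whether it would also appear with the hexyl chain. They also leave open whether a longer chain such as decyl on the phosphate, or a morpholine ring in place of the piperidine ring, would bring inhibition into the measurable range.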